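This account rests on a few compounds, and the source may have more. Where it says the series, first, only, none or still open, it means among the compounds named here.

Notes on the series, read in a physicochemical assay for solubility; on this read-out lower numbers stand for lower solubility and higher numbers for higher solubility. Compound 1 `O=C(Nc1ccc([N+](=O)[O-])cc1Cl)c1cc(-c2ccc(F)cc2F)ccc1O` gives < 1 ug/mL, which is a limit of the assay and not a number. Compound 2 `O=C(Nc1ccc(C(F)(F)F)cc1Cl)c1cc(-c2ccc(F)cc2F)ccc1O` gives < 1 ug/mL, again only a limit, so its true position is not known. The next structure is compound 3 `N#Cc1ccc(NC(=O)c2cc(-c3ccc(F)cc3F)ccc2O)c(Cl)c1`, and the change leading to it is cyano in place of trifluoromethyl on an aromatic carbon. Among the compounds with values here, the one measured step that bears on this position is a step that the two limits leave unreadable from compound 1 to compound 2, also a replacement at the same carbon, and its size cannot be read. Within the data shown here, with the limit of < 1 ug/mL in this assay, at which 2 of the 2 values shown sit, as the only evidence, no step beyond the scatter is expected in this assay, and no direction can be supported. The expected step is a step that the limit leaves unreadable from compound 2 to compound 3. Compound 3 is estimated at 0.8 ug/mL, with an expected range of 0.3 ug/mL to 3 ug/mL.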

Compound 3, solubility: < 1 ug/mL
Compound 3 ended at the assay's limit (the forecaster's own chance of this, stated with the estimate: 70%); the middle value is on the limit's open side.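

Within the data shown here, no step among compound 1, compound 2 and compound 3 can be read in this assay, since all three values are limits and not numbers: the limit of < 1 ug/mL in this assay, at which 3 of the 3 values shown sit. The compounds shown leave open where each truly lies, and whether nitro, trifluoromethyl and cyano at this aromatic carbon differ at all.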